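Aryl exchange on the shared core of compound 1

The compounds below may be only part of what the source reports. "The series", "measured", "known", "first", "only" and "open" are said of these compounds alone.

In a functional assay on COS-7 cells (Chlorocebus aethiops) for inhibition, read by MTT assay (a higher number here means a weaker inhibitor, a lower number a stronger inhibitor), compound 1 `O=C1Nc2ccc(Br)cc2/C1=N/NC(=S)N/N=C/c1c(F)cccc1Cl` gives 2560 nM, the lowest of the three numbers in hand. Compound 3 `COc1ccc(/C=N/NC(=S)N/N=C2\C(=O)Nc3ccc(C)cc32)cc1O` gives 3190 nM in this assay, which lies within the scatter of compound 1, so the two cannot be ordered. Among the compounds with values here, compound 2 `O=C1Nc2ccc(Br)cc2/C1=N/NC(=S)N/N=C/c1c(Cl)cccc1Cl` gives 6730 nM; the only measured step, a 2.6-fold higher number from compound 1 to compound 2 (0.42 log units; beyond the scatter), is a modest rise that lies beyond the scatter.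

Compound 4 `COc1ccc(/C=N/NC(=S)N/N=C2\C(=O)Nc3ccc(Br)cc32)cc1O` is not yet measured. It differs from compound 1 as follows: 3-hydroxy-4-methoxyphenyl in place of 2-chloro-6-fluorophenyl on a carbon with a double bond to nitrogen. Within the data shown here, no measured step carries this exchange directly. The step from compound 1 to compound 2 concerns a different change on the leaving ring and bears on it only insofar as it shows that substitution on that ring moves the number modestly. Compound 3 already carries the entering 3-hydroxy-4-methoxyphenyl, though on a core that differs from that of compound 1, and its value sits within the scatter of compound 1; this is the closest indirect pointer and suggests no step beyond the scatter. Compound 4 is therefore expected to give 2800 nM, with a range of 1300 nM to 6000 nM; the estimated step of a 1.1-fold higher number from compound 1 to compound 4 (0.04 log units; within the scatter) is within the scatter.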

Compound 4, half-maximal inhibitory concentration: 3090 nM
The estimate for compound 4 lay 1.1-fold (0.04 log units) below the measured number; the range from low to high includes it.
By their numbers in this assay, from the lowest: compounds 1, 4 and 3 (each within the scatter of the next); then compound 2.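

In this assay, the exchange of 2-chloro-6-fluorophenyl for 3-hydroxy-4-methoxyphenyl on the carbon with a double bond to nitrogen gives a 1.2-fold higher number from compound 1 to compound 4 (0.08 log units; within the scatter), so this position accepts an aryl group without halogen, carrying a hydrogen-bond donor and hydrogen-bond acceptors, with no step beyond the scatter. With 3-hydroxy-4-methoxyphenyl held in place, bromo in place of methyl on an aromatic carbon gives a 1.0-fold lower number from compound 3 to compound 4 (0.01 log units; within the scatter), so that exchange on the core does not separate the two compounds. Within the data shown here, the exchange of 2,6-dichlorophenyl for 3-hydroxy-4-methoxyphenyl gives a 2.2-fold lower number from compound 2 to compound 4 (0.34 log units; beyond the scatter), which, together with the step from compound 1 to compound 2, sets compound 2 apart from compound 1 and compound 4 and makes 2,6-dichlorophenyl the only aryl group here linked to a step beyond the scatter.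

Still open, going by these compounds, is whether an aryl group bearing an amine or a carboxylic acid, or a longer chain such as butoxy in place of the methoxy, would keep the number within the scatter of compound 4, and whether methyl in place of bromo would also pass unnoticed with 2-chloro-6-fluorophenyl on the carbon with a double bond to nitrogen. Nothing at hand offers an explanation for any of these steps.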